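The source may hold more compounds than are shown below. What is called first, only, known or untested is meant among the compounds shown, and "the series" means these compounds.

Measured compounds:
Compound 1, `COC(=O)CCNC(=O)[C@@H]1O[P@@](=O)(OCOC(=O)c2scnc2C(C)(C)C)OCC1(C)C`: in an ADME assay on blood (Homo sapiens) for pharmacokinetics (on this read-out lower numbers stand for a shorter-lived compound and higher numbers for a longer-lived compound), compound 1 gives > 1 h, which is a limit of the assay.
Compound 2, `CCc1cc(C(=O)OCO[P@]2(=O)OCC(C)(C)[C@H](C(=O)NCCC(=O)OC)O2)n(C)n1`: in this assay compound 2 gives < 0.16 h, which is also a limit of the assay.

Neither measured value is a number, so only limits are known. Among the compounds with values here, compound 2 sits at the lower end of what the assay reports, while compound 1 sits at the upper end, and no step between two measured compounds connects them. Compound 3, `CCc1cc(C(=O)OCO[P@@]2(=O)OCC(C)(C)[C@H](C(=O)NCCC(=O)OC)O2)n(C)n1`, differs from compound 2 in this way: the two compounds have the same atoms and bonds and differ only in configuration as drawn: 1 of 2 stereo elements differ; a stereocentre at a phosphorus is drawn R in compound 2 and S in compound 3. Within the data shown here, with no measured step to draw on, the direction of the change at phosphorus is uncertain; a modest lengthening toward a reportable value seems as plausible as no change beyond the scatter. Compound 3 is expected to give 0.3 h in this assay, within a range of 0.1 h to 1.2 h, which means an expected step of an at least 1.8-fold higher number from compound 2 to compound 3 (0.27 log units; that floor lies within the scatter).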

Compound 3, half-life: >= 0.97 h
Compound 3: only a limit was reported; the forecaster's own chance of this, stated with the estimate: 50%; middle value at least 3.2-fold (0.50 log units) away from the limit.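

Within the data shown here, compound 1 and compound 2 shared no measured step, so they could not show what any single change does in this assay. The inversion at phosphorus now supplies such a step, an at least 6.0-fold higher number from compound 2 to compound 3 (0.78 log units; beyond the scatter), and it can be assigned to the phosphorus stereocentre alone because of this: the fact that compounds 2 and 3 differ only in the configuration as drawn. Compound 3 gives >= 0.97 h, which is a limit of the assay, so the step has a floor but no measured size.

The step from compound 1 to compound 3, with 3-ethyl-1-methyl-1H-pyrazol-5-yl in place of 4-(tert-butyl)-1,3-thiazol-5-yl on a carbonyl carbon, cannot be read, since both values are limits. Going by these compounds, it remains open whether the configuration at phosphorus carries the same weight with another group on that carbonyl carbon, such as a phenyl group.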